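Tert-Butylamide in Place of the Ethyl Ester

This account rests on a few compounds, and the source may have more. Where it says the series, first, only, none or still open, it means among the compounds named here.

Compound 1 `COC(=O)/C=C/c1cccc(N(Cc2ccc(/C=C/c3ccccc3F)cc2)C(=O)C2CCCCC2)c1` sets the reference: in an assay on isolated protein with Bile acid receptor (Homo sapiens) as the target (a higher number here means that more compound is needed for the effect, a lower number that less compound is needed), compound 1 gives 64 nM. Compound 2 `CCOC(=O)/C=C/c1ccc(CN(C(=O)C2CCCCC2)c2cccc(/C=C/C(=O)OC)c2)cc1` carries an ethoxycarbonyl where compound 1 carries a 2-fluorophenyl, and the step of an at least 15-fold higher number from compound 1 to compound 2 (1.19 log units; beyond the scatter) runs against it. In this assay compound 2 reaches only > 1000 nM, which is a limit of the assay and not a number (the limit of > 1000 nM in this assay, at which 1 of the 2 values shown sits). Compound 3 `COC(=O)/C=C/c1cccc(N(Cc2ccc(/C=C/C(=O)NC(C)(C)C)cc2)C(=O)C2CCCCC2)c1` differs from compound 2 in one place: (tert-butyl)amino in place of ethoxy on a carbonyl carbon. No measured step touches this change directly; the only step shown concerns the other end of that arm, where the ethoxycarbonyl itself replaced the 2-fluorophenyl and brought the large loss. Whether the (tert-butyl)amino improves on the ethoxy cannot be read from these two compounds. Because compound 2 stands at the limit > 1000 nM, the starting point for compound 3 is itself uncertain. Compound 3 is therefore expected to remain weak, at an estimated 1500 nM within a range from 400 nM to 6000 nM. The step this estimate implies is expected to be a step that the limit leaves unreadable from compound 2 to compound 3.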

Compound 3, half-maximal effective concentration: > 1000 nM
Compound 3 gave a limit, no number; the forecaster's own chance of this, stated with the estimate: 55%; the middle value is on the limit's open side.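

The second replacement of the 2-fluorophenyl on the double-bonded chain carbon, now by (tert-butyl)carbamoyl, gives an at least 15-fold higher number from compound 1 to compound 3 (1.19 log units; beyond the scatter). The large loss first seen with the ethoxycarbonyl is therefore not confined to that group: among the compounds shown, both replacements at this position go the same way, and only compound 1, with its 2-fluorophenyl, gives a number. In this assay compound 3 stands at > 1000 nM, which is a limit of the assay and not a number, so the step between compound 2 and compound 3 cannot be read and the change from ethoxy to (tert-butyl)amino cannot be judged: the limit of > 1000 nM in this assay, at which 2 of the 3 values shown sit.

Going by these compounds, what stays open is how far the true values of compound 2 and compound 3 lie past that limit, and so whether the two groups differ at all. Also open is whether a plain phenyl, a 2-chlorophenyl or a pyridine ring on that carbon would hold the value of compound 1, or whether a carboxylic acid there would fare any better than the two groups shown.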